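Pyrazole to oxazole on the urea-linked methylene

The source may hold more compounds than are shown below. What is called first, only, known or untested is meant among the compounds shown, and "the series" means these compounds.

Measured so far:
compound 1 `CCOC(=O)c1ccc(NC(=O)NCc2c[nH]nn2)cc1` — 7750 nM
compound 2 `O=C(NCc1cn[nH]c1)Nc1ccc(S(=O)(=O)c2ccccc2)cc1` — 28 nM

In an assay on isolated protein for activation of Nicotinamide phosphoribosyltransferase (Homo sapiens) (on this read-out lower numbers stand for an effect already at smaller amounts and higher numbers for an effect only at larger amounts of compound), compound 2 gives the lower of the two numbers, and its gap to compound 1 lies beyond the scatter; the two also differ in the aryl group, so the gap cannot be traced to one place. Compound 3 `O=C(NCc1cnco1)Nc1ccc(S(=O)(=O)c2ccccc2)cc1` carries 1,3-oxazol-5-yl in place of 1H-pyrazol-4-yl on a saturated chain carbon bound to an amide-type nitrogen. For the measured compounds named here, no pair differing only here has been measured, so the expectation rests on the loss of the one hydrogen-bond donor. A moderate step upward, beyond the scatter, is expected for compound 3, with a 3.9-fold higher number from compound 2 to compound 3 (0.59 log units; beyond the scatter). Compound 3 is estimated at 110 nM, within 30 nM to 450 nM.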

Compound 3, half-maximal effective concentration: 77 nM
The estimate for compound 3 lay 1.4-fold (0.15 log units) above the measured number; low and high end bracket the measured number.
By their numbers in this assay, from the lowest: compound 2; then compound 3; then compound 1.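

The first pair differing in one place isolates the ring on a saturated chain carbon bound to an amide-type nitrogen: in this assay, 1,3-oxazol-5-yl in place of 1H-pyrazol-4-yl gives a 2.8-fold higher number from compound 2 to compound 3 (0.44 log units; beyond the scatter). Compound 3, whose ring carries 0 hydrogen-bond donors, still gives 77 nM, so a donor on this ring is not required for activation. No supporting data bear on the origin of this step.

Open, as far as these compounds go, is whether a six-membered pyridin-3-yl ring would hold the number here, and whether the same exchange behaves alike with the ethyl ester aryl group of compound 1.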